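Chloro on the benzyl ring of compound 2

The source may report more compounds than this note shows. Statements on the series, on what has been measured and on what is new or still open speak of the compounds shown alone.

Compound 1 `CC(C)CCn1cc(/C=C/C(=O)CC(=O)C(=O)O)c2ccccc21` and compound 2 `O=C(/C=C/c1cn(Cc2ccccc2)c2ccccc12)CC(=O)C(=O)O` have been measured in an assay on isolated protein for inhibition of DNA nucleotidylexotransferase (Homo sapiens), read by scintillation counting, with a stated time of 10 min; on this read-out lower numbers stand for stronger inhibition and higher numbers for weaker inhibition. Compound 1 gives 16.3 uM, and compound 2 gives 7.9 uM, the lowest of the two numbers; the step of a 2.1-fold lower number from compound 1 to compound 2 (0.31 log units; beyond the scatter) separates them. Compound 3 `O=C(/C=C/c1cn(Cc2ccc(Cl)cc2)c2ccccc12)CC(=O)C(=O)O` carries chloro in place of hydrogen on an aromatic carbon. For the measured compounds named here, no measured pair shows this change; the one measured step concerns the group on the saturated chain carbon bound to the aromatic nitrogen, not a substituent on that phenyl. In this assay only a small step is therefore expected, estimated as a 1.3-fold lower number from compound 2 to compound 3 (0.12 log units; within the scatter). Compound 3 is expected to give 6 uM, within 2.5 uM to 15 uM.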

Compound 3, concentration for 50% inhibition: 10 uM
Compound 3: middle estimate off by 1.7-fold (0.22 log units), on the low side, and the stated range covers the measured number.
By their numbers in this assay, from the lowest: compounds 2, 3 and 1 (each within the scatter of the next, the first and the last beyond it).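

In this assay, for the compounds shown here, a substituent on the phenyl ring appears for the first time: chloro in place of hydrogen gives a 1.3-fold higher number from compound 2 to compound 3 (0.10 log units; within the scatter) and so leaves the number within the scatter. Relative to the isobutyl group, 4-chlorophenyl gives a 1.6-fold lower number from compound 1 to compound 3 (0.21 log units; within the scatter) and also stays within the scatter, while unsubstituted phenyl gave a 2.1-fold lower number from compound 1 to compound 2 (0.31 log units; beyond the scatter) and lay just beyond it. No measured evidence accounts for either step.

Still open, going by these compounds, is whether methoxy, an amine or a carboxylic acid at this place, or chloro elsewhere on the phenyl ring, would move the number beyond the scatter.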